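Swapping fluoro for bromo on a weak inhibitor

The source may report more compounds than this note shows. Statements on the series, on what has been measured and on what is new or still open speak of the compounds shown alone.

Compound 1 `CC1(C)CC(NC(=O)Nc2ccccc2Cl)c2cc(F)ccc2O1` gives 27000 nM
Compound 2 `CC1(C)CC(NC(=O)Nc2ccccc2)c2cc(Cl)ccc2O1` gives 34000 nM
Compound 3 `CC1(C)CC(NC(=O)Nc2ccc(Cl)cc2)c2cc(F)ccc2O1` gives 30000 nM

All of these numbers come from a functional assay on T98G cells (Homo sapiens) for inhibition, read by MTT assay, with a stated time of 72 h (on this read-out lower numbers stand for stronger inhibition and higher numbers for weaker inhibition), and they lie within the scatter of one another, so compound 1 has no real separation from the other two. The next compound, compound 4 `CC1(C)CC(NC(=O)Nc2ccccc2Cl)c2cc(Br)ccc2O1`, keeps the core of compound 1 and changes a single group: bromo in place of fluoro on an aromatic carbon. In words, this is bromo in place of fluoro on an aromatic carbon.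

Within the data shown here, no measured step changes only this group, so the evidence is indirect. Among the measured compounds shown here, the one measured step, a 1.1-fold higher number from compound 1 to compound 3 (0.05 log units; within the scatter), concerns a different part of the molecule. Compound 1 and compound 2 differ in two places, one of them this same carbon, where compound 2 carries chloro and gives 34000 nM. That value lies within the scatter of the value for compound 1. A change beyond the scatter is therefore not expected in this assay, and no direction can be favoured. The estimated step is a 1.0-fold lower number from compound 1 to compound 4 (0.02 log units; within the scatter). For compound 4 the expected value is 26000 nM, with an estimated range of 14000 nM to 46000 nM.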

Compound 4, half-maximal inhibitory concentration: 11000 nM
The estimate for compound 4 lay 2.4-fold (0.37 log units) above the measured number; the measured number lies below the stated range.
By their numbers in this assay, from the lowest: compound 4; then compounds 1, 3 and 2 (each within the scatter of the next).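

In this assay, among these compounds, bromo in place of fluoro gives a 2.5-fold lower number from compound 1 to compound 4 (0.39 log units; beyond the scatter), a modest change but the first single-group step here to lie beyond the scatter. Among the compounds shown here, the earlier measured step, a 1.1-fold higher number from compound 1 to compound 3 (0.05 log units; within the scatter), stayed within the scatter, so this aromatic carbon is the first place where one change clearly moves the number, and the swap involves just one heavy atom for another. Nothing measured here explains why the number falls at this position.

Going by these compounds, it remains open whether other groups on this carbon, such as iodo, methoxy or an amine, would lower the number further, leave it unchanged or raise it. On these data alone, it is also open whether bromo would give a similar step on compound 3, which carries a different chlorophenyl group.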